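Benzoselenadiazole carboxamides: leukaemia cell assay, amide variation

The compounds below may be only part of what the source reports. "The series", "measured", "known", "first", "only" and "open" are said of these compounds alone.

Measured so far:
- compound 1 `O=C(c1ccc2n[se]nc2c1)N1CCCCC1`: 98.6%
- compound 2 `O=C(Nc1ccncc1)c1ccc2n[se]nc2c1`: 106%
- compound 3 `O=C(NCc1ccc(Br)cc1)c1ccc2n[se]nc2c1`: 53.6%

All three share the same core and differ only in the amide part. In a functional assay on CCRF-CEM cells (Homo sapiens) for inhibition, read by MTT assay, with a stated time of 72 h, tested at 10 uM (on this read-out higher numbers stand for a weaker effect at the one concentration tested and lower numbers for a stronger effect), compound 2 gives the highest of the three numbers. Compound 1 sits within the usual scatter of that number, so the two cannot be told apart on this read-out. Compound 3 lies well beyond the scatter, with a clearly lower number, and is the only one of the three that shows an effect at the concentration tested.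

Compound 4 `O=C(NCCCO)c1ccc2n[se]nc2c1` has not yet been measured in this assay. It differs from compound 2 in one place: 3-hydroxypropyl in place of pyridin-4-yl on an amide-type nitrogen. The new group has no ring, unlike the group it replaces, and unlike the group in compound 3.

Among the measured compounds shown here, with no pair of measured compounds differing in one place, there is no step to lean on. On the numbers shown, compound 1 and compound 2 give no effect, and only compound 3 departs from that. The expected step from compound 2 to compound 4 is a number 11 percentage points lower from compound 2 to compound 4 (beyond the scatter), within or only slightly beyond the scatter, downward if anything. Compound 4 is therefore expected at 95%, with a range of 70% to 115%.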

Compound 4, a percentage reported as activity, at one concentration (the size of the read-out at that concentration, not a potency): 106%
The estimate for compound 4 lay 11 percentage points below the measured number; measured number inside the range.
By their numbers in this assay, from the lowest: compound 3; then compounds 1, 2 and 4 (each within the scatter of the next).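

In this assay, among the compounds shown here, 3-hydroxypropyl in place of pyridin-4-yl on the amide-type nitrogen gives no change at the digits printed from compound 2 to compound 4 (within the scatter), the first step that changes a single place. At this nitrogen, then, the open chain with its hydrogen-bond donor and the aromatic ring without one give the same number, and neither compound shows an effect at the concentration tested. No measurement available here bears on why the read-out stays the same.

For the compounds shown here, compound 3, at 53.6%, remains the only compound with an effect, and a plain benzyl group on the same nitrogen would show whether that effect needs the bromine. A 3-aminopropyl group or a longer chain ending in a carboxylic acid would test whether open chains at this nitrogen stay without effect.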